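The source may hold more compounds than are shown below. What is called first, only, known or untested is meant among the compounds shown, and "the series" means these compounds.

Measured so far:
- compound 1 `COc1cc(C(=O)c2cn(-c3cccc(C)c3)cc2-c2cccc([N+](=O)[O-])c2)cc(OC)c1OC`: 880 nM
- compound 2 `COc1cc(C(=O)c2cn(-c3cccc(C)c3)cc2-c2ccc([N+](=O)[O-])cc2)cc(OC)c1OC`: 780 nM
- compound 3 `COc1cc(C(=O)c2cn(-c3ccc(C)cc3)cc2-c2cccc([N+](=O)[O-])c2)cc(OC)c1OC`: 210 nM

All three were tested in a functional assay on MCF7 cells (Homo sapiens) for cytotoxicity, read by MTT assay, with a stated time of 96 h; on this read-out higher numbers stand for weaker inhibition and lower numbers for stronger inhibition. Compound 1 and compound 2 differ in a single place: 4-nitrophenyl in place of 3-nitrophenyl on an aromatic carbon. That change produced a 1.1-fold lower number from compound 1 to compound 2 (0.05 log units; within the scatter), so the two numbers cannot be told apart. Compound 1 and compound 3 differ in another place, on the ring nitrogen of the shared core: 4-methylphenyl in place of 3-methylphenyl on an aromatic nitrogen. That change produced a 4.2-fold lower number from compound 1 to compound 3 (0.62 log units; beyond the scatter), and compound 3 gives the lowest number of the three, with gaps to compound 1 and to compound 2 that lie beyond the scatter.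

Compound 4 `COc1cc(C(=O)c2cn(-c3ccc(C)cc3)cc2-c2ccc([N+](=O)[O-])cc2)cc(OC)c1OC` has not yet been measured in this assay. It differs from compound 3 in one place: 4-nitrophenyl in place of 3-nitrophenyl on an aromatic carbon. Among the measured compounds shown here, this is the same kind of change as the one from compound 1 to compound 2, not the same change: around the place, the ring atom two ring bonds away bears a 4-methylphenyl group in compound 3 but a 3-methylphenyl group in compound 1.

The step from compound 3 to compound 4 is expected to be small, a 1.1-fold lower number from compound 3 to compound 4 (0.04 log units; within the scatter), because the earlier step of a 1.1-fold lower number from compound 1 to compound 2 (0.05 log units; within the scatter) lay within the scatter. On that basis compound 4 is estimated at 190 nM, most likely between 90 nM and 450 nM.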

Compound 4, half-maximal inhibitory concentration: 200 nM
Compound 4: middle estimate off by 1.1-fold (0.02 log units), on the low side, within the range that was stated.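

In this assay, replacing 3-nitrophenyl with 4-nitrophenyl again left the number effectively unchanged (a 1.1-fold lower number from compound 3 to compound 4 (0.02 log units; within the scatter)), and this small step carried over from one core to the other: the same change on two cores in this assay, a 1.1-fold lower number (0.05 log units; within the scatter) from compound 1 to compound 2 and a 1.1-fold lower number (0.02 log units; within the scatter) from compound 3 to compound 4, 1.1-fold (0.03 log units) apart, within the scatter of two such steps.

Replacing 3-methylphenyl with 4-methylphenyl on the ring nitrogen again gave a lower number (a 3.9-fold lower number from compound 2 to compound 4 (0.59 log units; beyond the scatter)), and this larger step also kept its size on the second core: the same change on two cores in this assay, a 4.2-fold lower number (0.62 log units; beyond the scatter) from compound 1 to compound 3 and a 3.9-fold lower number (0.59 log units; beyond the scatter) from compound 2 to compound 4, 1.1-fold (0.03 log units) apart, within the scatter of two such steps.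

Across these four compounds, then, the effect of each change did not depend on which form of the other group was present, so the two changes can be read separately; this does not explain why the methylphenyl change matters, and with only one pair of steps for each change, it does not show that the same would hold on other cores or with other groups.

The compounds shown carry only nitrophenyl and methylphenyl groups at these two places, so it remains open whether the same independence would hold with an amine or a carboxylic acid in place of the nitro group. As far as these compounds go, it is also open whether a longer chain, such as ethyl or propyl, in place of the methyl group would keep, lose or extend the lower number seen with 4-methylphenyl.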